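Swapping Cyano for Trifluoromethyl on a Well-Tolerated Aryl Position

The source may hold more compounds than are shown below. What is called first, only, known or untested is meant among the compounds shown, and "the series" means these compounds.

Measured compounds:
compound 1 `O=C1CCCc2cc(OCc3ccc(Br)cc3)ccc21` gives 9 nM
compound 2 `Cc1ccc(COc2ccc3c(c2)CCCC3=O)cc1` gives 11 nM
compound 3 `N#Cc1ccc(COc2ccc3c(c2)CCCC3=O)cc1` gives 11 nM

In an assay on isolated protein for inhibition of Amine oxidase [flavin-containing] B (Homo sapiens), read by fluorescence and spectrophotometry, with a stated time of 30 min (on this read-out lower numbers stand for stronger inhibition and higher numbers for weaker inhibition), the three measured compounds lie close together. Compound 3 stands level with compound 2 at the digits given, and the two share the highest numbers of the three; the step of no change at the digits printed from compound 2 to compound 3 (within the scatter) is its nearest, the step of a 1.2-fold higher number from compound 1 to compound 3 (0.09 log units; within the scatter) its furthest. Compound 4 `O=C1CCCc2cc(OCc3ccc(C(F)(F)F)cc3)ccc21` differs from compound 3 by trifluoromethyl in place of cyano on an aromatic carbon. Every measured step concerns a swap of the group on that same aromatic carbon: a 1.2-fold higher number from compound 1 to compound 2 (0.09 log units; within the scatter), a 1.2-fold higher number from compound 1 to compound 3 (0.09 log units; within the scatter) and no change at the digits printed from compound 2 to compound 3 (within the scatter) all fall within the scatter. The expected step is therefore a 1.1-fold higher number from compound 3 to compound 4 (0.04 log units; within the scatter), with no change beyond the scatter in this assay. Compound 4 is estimated at 12 nM, within a range from 5 nM to 30 nM.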

Compound 4, half-maximal inhibitory concentration: 6 nM
Estimate against measurement, compound 4: 2.0-fold (0.30 log units) above; the range from low to high includes it.
By their numbers in this assay, from the lowest: compounds 4, 1, 2 and 3 (each within the scatter of the next).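

In this assay, trifluoromethyl on this aromatic carbon stays within the scatter of all three earlier groups: a 1.8-fold lower number from compound 3 to compound 4 (0.26 log units; within the scatter), a 1.8-fold lower number from compound 2 to compound 4 (0.26 log units; within the scatter), and a 1.5-fold lower number from compound 1 to compound 4 (0.18 log units; within the scatter). At this place, para to a large group, four heavy atoms with no hydrogen-bond acceptor therefore read the same as cyano with its one acceptor, so this change gives no step beyond the scatter. Nothing available gives a reason for this result. As far as these compounds go, whether an amine or a carboxylic acid on this carbon would also stay within the scatter remains open. So does the effect of a longer chain there, or of any change to the shared core.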